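The compounds below may be only part of what the source reports. "The series", "measured", "known", "first", "only" and "open" are said of these compounds alone.

Measured so far:
compound 1 `CCCCN(C)/N=N/c1n[nH]cc1C(=O)OCC` gives 3.16 in a functional assay on L1210 cells (Mus musculus) for antiproliferative activity; on this read-out higher numbers stand for higher potency (the scale is a negative logarithm) and lower numbers for lower potency;
compound 2 `CCCN(C)/N=N/c1n[nH]cc1C(N)=O` gives 3.7 in this assay.

Compound 2 stands highest of the two numbers; its nearest neighbour is compound 1, whose number is lower by more than the usual scatter. For the measured compounds named here, compound 1 and compound 2 differ in more than one place, so the two values alone show the gap and no single step is known. Compound 3 `CCCCN(C)/N=N/c1n[nH]cc1C(N)=O` differs from compound 2 by methyl in place of hydrogen on a saturated chain carbon, three bonds along the chain from an amine nitrogen. Going by the values given here, with no measured step covering this change, the expected step in this assay is small, in no firm direction, likely within the scatter. Compound 3 is estimated at 3.7, range 3.2 to 4.2, which is an expected step of no change at the digits printed from compound 2 to compound 3 (within the scatter).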

Compound 3, logarithm of the reciprocal of the active concentration, log(1/C): 3.81
For compound 3 the middle estimate is 0.11 log units below the measured one; the measured number falls inside the stated range.
By their numbers in this assay, from the lowest: compound 1; then compounds 2 and 3 (each within the scatter of the next).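

Propyl to butyl, on a saturated chain carbon three bonds along the chain from an amine nitrogen, gives a number 0.11 log units higher from compound 2 to compound 3 (within the scatter) in this assay and is the first single change read at this position. Compound 3 also isolates amino in place of ethoxy on a carbonyl carbon, with a number 0.65 log units higher from compound 1 to compound 3 (beyond the scatter) as a step that the two earlier compounds could not separate from the chain difference. No measurement shown accounts for either step. As far as these compounds go, a chain longer than butyl remains open at the first position, and a carboxylic acid remains open at the carbonyl carbon.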